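Working notes: replacing bromo with cyano in the series

The source may hold more compounds than are shown below. What is called first, only, known or untested is meant among the compounds shown, and "the series" means these compounds.

Measured in a functional assay on the whole organism for positive allosteric modulation, with Mus musculus as the target; on this read-out lower numbers stand for an effect already at smaller amounts and higher numbers for an effect only at larger amounts of compound:
- Compound 1 `CCC(=O)N(c1ccc(C)cc1)C1CCCC1N(C)C`: 30 mg/kg; 30 mg/kg (2 entries)
- Compound 2 `CCC(=O)N(c1ccc(F)cc1)C1CCCC1N(C)C`: 5 mg/kg
- Compound 3 `CCC(=O)N(c1ccc(Br)cc1)C1CCCC1N(C)C`: 2 mg/kg

In this assay, compound 3 has the lowest number of the three, at 2 mg/kg. The next step leads to compound 4 `CCC(=O)N(c1ccc(C#N)cc1)C1CCCC1N(C)C`, which has not yet been measured. The change is cyano in place of bromo on an aromatic carbon, para to a large group: cyano in place of bromo on an aromatic carbon.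

Among the measured compounds shown here, the only measured step between two compounds that differ in one place is a 2.5-fold lower number from compound 2 to compound 3 (0.40 log units; beyond the scatter). It is modest, lies beyond the scatter and exchanges one halogen for another, so it bears on the new step only indirectly. For the measured compounds named here, no cyano compound has been measured. The values also show a wider spread: compound 1 stands at 30 mg/kg; 30 mg/kg (2 entries), a higher number than compound 3 at 2 mg/kg. Compound 3 sits at the low end of this small set, so a move to a higher number is expected, of a size somewhat larger than the modest halogen step. The expected change is a 4.0-fold higher number from compound 3 to compound 4 (0.60 log units; beyond the scatter). For compound 4 the estimate is 8 mg/kg, with an expected range of 2 mg/kg to 30 mg/kg.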

Compound 4, dose for half-maximal effect: 10 mg/kg
Compound 4: middle estimate off by 1.3-fold (0.10 log units), on the low side; the measured number falls inside the stated range.
By their numbers in this assay, from the lowest: compound 3; then compounds 2 and 4 (each within the scatter of the next).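

In this assay, cyano on the aromatic carbon para to a large group gives a 5.0-fold higher number from compound 3 to compound 4 (0.70 log units; beyond the scatter), so this position responds to a replacement beyond the exchange of one halogen for another, here with 2 heavy atoms and 1 hydrogen-bond acceptor entering in place of the single bromine. Bromo now stands apart from both other electron-poor-free comparisons at this place in the series: alongside a 2.5-fold lower number from compound 2 to compound 3 (0.40 log units; beyond the scatter), the cyano compound adds a second step beyond the scatter away from compound 3, whereas a 2.0-fold higher number from compound 2 to compound 4 (0.30 log units; within the scatter) leaves cyano and fluoro unseparated in this assay. No measurement in hand accounts for the difference between bromo and cyano at this position.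

The compounds shown leave open whether the low number of compound 3 belongs to bromo alone or would also appear with chloro or iodo at the same place. They also leave open how a trifluoromethyl, a methoxy or a carboxylic acid would read at this position, and whether the step from bromo to cyano would hold with a chain other than the propanoyl group on the shared core.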